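Piperidin-1-yl replaces (dimethylamino)methyl on the side chain

The compounds below may be only part of what the source reports. "The series", "measured", "known", "first", "only" and "open" are said of these compounds alone.

Measured in a functional assay on cells (Neutrophil, Homo sapiens) for inhibition, read by transwell migration (on this read-out higher numbers stand for weaker inhibition and lower numbers for stronger inhibition), so far:
compound 1 `CCOC(=O)c1c(NCCN(CC)CC)n(-c2ccccc2)c(=S)n(-c2ccccc2)c1=O` gives 0.02 nM
compound 2 `CCOC(=O)c1c(NCCCN(C)C)n(-c2ccccc2)c(=S)n(-c2ccccc2)c1=O` gives 3.89 nM

Compound 2 holds the higher of the two numbers and is the weaker inhibitor of the pair. Among the measured compounds shown here, the only measured step is a 190-fold higher number from compound 1 to compound 2 (2.29 log units; beyond the scatter), in which (dimethylamino)methyl took the place of diethylamino. The next compound is compound 3 `CCOC(=O)c1c(NCCN2CCCCC2)n(-c2ccccc2)c(=S)n(-c2ccccc2)c1=O`, and its difference from compound 2 is piperidin-1-yl in place of (dimethylamino)methyl on a saturated chain carbon, two bonds along the chain from a nitrogen on an aromatic ring. Piperidin-1-yl thus replaces (dimethylamino)methyl on the saturated chain carbon.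

This change removes the same group that the measured step brought in, so that step is the one bearing on it, read backwards. For the measured compounds named here, compound 3 does not regain diethylamino, however, and no compound carrying piperidin-1-yl has a value yet. Compound 1 at 0.02 nM therefore marks the far end of what might be recovered in this assay, and only part of that distance is expected. The expected move is a 19-fold lower number from compound 2 to compound 3 (1.29 log units; beyond the scatter), towards stronger inhibition. Compound 3 is estimated at 0.2 nM, with an expected range from 0.02 nM to 2 nM in repeated measurements.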

Compound 3, half-maximal inhibitory concentration: 85.4 nM
Compound 3: the middle estimate sits 430-fold (2.63 log units) below what was measured; the measured number lies above the stated range.
By their numbers in this assay, from the lowest: compound 1; then compound 2; then compound 3.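

In this assay, piperidin-1-yl in place of (dimethylamino)methyl gives a 22-fold higher number from compound 2 to compound 3 (1.34 log units; beyond the scatter), so removing that group does not by itself bring the number down towards that of compound 1, and compound 3 is the weakest inhibitor of the three. Set against diethylamino on the same saturated chain carbon, piperidin-1-yl gives a 4300-fold higher number from compound 1 to compound 3 (3.63 log units; beyond the scatter), which shows that this place sharply separates these two amine groups and that the very low number of compound 1 does not carry over to a six-membered non-aromatic ring there. Nothing at hand gives a reason for either step.

The compounds shown leave open whether a pyrrolidin-1-yl ring, or a morpholin-4-yl ring with its ring oxygen, would fall nearer compound 1 or nearer compound 3 in this assay. Also open, going by these compounds, is how much of the gap between compound 1 and compound 2 goes with the end group and how much with the chain, a question that dimethylamino on this same carbon or a 3-(diethylamino)propyl chain would address.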